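Aminopyrimidine series: cytotoxicity on murine BaF3 cells

This account rests on a few compounds, and the source may have more. Where it says the series, first, only, none or still open, it means among the compounds named here.

Measured compounds:
compound 1 `CC(C)Cn1cc(-c2cc(Nc3ccc(OC(F)(F)F)cc3)ncn2)cn1` — > 10000 nM in an ADME assay on BaF3 cells (Mus musculus) for cytotoxicity; on this read-out lower numbers stand for an effect already at smaller amounts and higher numbers for an effect only at larger amounts of compound
compound 2 `FC(F)(F)Oc1ccc(Nc2cc(-c3ccncc3)ncn2)cc1` — > 10000 nM

In this assay compound 1 stands at a limit of the assay, not a number, with > 10000 nM. Compound 2 likewise stands at a limit, > 10000 nM. Among the measured compounds shown here, the one measured step, a step that the two limits leave unreadable from compound 1 to compound 2, therefore cannot be sized; it rests on (the limit of > 10000 nM in this assay, at which 2 of the 2 values shown sit).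

The next compound, compound 3 `NC(=O)c1ccccc1-c1cc(Nc2ccc(OC(F)(F)F)cc2)ncn1`, differs from compound 2 by 2-carbamoylphenyl in place of pyridin-4-yl on an aromatic carbon. For the measured compounds named here, no measured step bears on this change beyond the unreadable one from compound 1 to compound 2, and both measured values sit at the same limit, so no direction can be read and no step beyond the scatter is anticipated. Compound 3 is expected to give 12000 nM (range 4000 nM to 40000 nM), most likely again as a limit. The expected step for compound 3 is a step that the limit leaves unreadable from compound 2 to compound 3.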

Compound 3, half-maximal effective concentration: > 10000 nM
Compound 3 gave a limit, no number (the forecaster's own chance of this, stated with the estimate: 80%); the middle value lies beyond the limit too.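

Among the compounds shown here, compound 3, like compound 1 and compound 2, gives a limit rather than a number in this assay, so no step among them can be read: the limit of > 10000 nM in this assay, at which 3 of the 3 values shown sit. The compounds shown leave open whether any change on the shared core would give a readable value in this assay.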